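The source may hold more compounds than are shown below. What is called first, only, known or untested is meant among the compounds shown, and "the series" means these compounds.

- compound 1 `COc1ccc(/C=C2\CN(C)C/C(=C\c3cccnc3)C2=O)c(OC)c1OC` at 5160 nM
- compound 2 `CN1C/C(=C\c2cccnc2)C(=O)/C(=C/c2ccc(F)cc2Br)C1` at 13000 nM
- compound 3 `CN1C/C(=C\c2cccnc2)C(=O)/C(=C/c2ccccc2C(F)(F)F)C1` at 2550 nM

For the measured compounds named here, these three values all come from a functional assay on HepG2 cells (Homo sapiens) for cytotoxicity, read by MTT assay, with a stated time of 24 h (a lower number here means a stronger inhibitor, a higher number a weaker inhibitor), and are the only readings so far. Compound 2 stands highest of the three and is the weakest inhibitor here, with compound 1 and compound 3 both lower by more than the scatter.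

Next in line is compound 4 `CN1C/C(=C\c2ccc(C#N)cc2)C(=O)/C(=C/c2cccnc2)C1` which differs from compound 2 in one place: 4-cyanophenyl in place of 2-bromo-4-fluorophenyl on a double-bonded chain carbon bound to a double-bonded ring carbon with 4-cyanophenyl in place of 2-bromo-4-fluorophenyl on a double-bonded chain carbon bound to a double-bonded ring carbon.

Going by the values given here, no two measured compounds differ in one place only, so no measured step shows what such an exchange does in this assay and the expectation rests on the spread of values alone. Compound 2 at 13000 nM sits at the top of that spread, while compound 1 at 5160 nM and compound 3 at 2550 nM carry other groups at that place and lie lower. Leaving the group of compound 2 is therefore expected to bring a lower number, not a higher one. The estimated change is a 2.6-fold lower number from compound 2 to compound 4 (0.41 log units; beyond the scatter) and it remains a loosely grounded expectation. For compound 4 the estimated value is 5000 nM with an expected range of 1500 nM to 14000 nM as its bounds.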

Compound 4, half-maximal inhibitory concentration: 12700 nM
Beside the measured number, compound 4's estimate is 2.5-fold (0.40 log units) below it; measured number inside the range.
By their numbers in this assay, from the lowest: compound 3; then compound 1; then compounds 4 and 2 (each within the scatter of the next).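

In this assay, for the compounds shown here, this is the first exchange that can be read at a single place: 4-cyanophenyl in place of 2-bromo-4-fluorophenyl on a double-bonded chain carbon bound to a double-bonded ring carbon gives a 1.0-fold lower number from compound 2 to compound 4 (0.01 log units; within the scatter), which lies within the scatter. At this place, a phenyl ring carrying a nitrile therefore cannot be told apart from one carrying bromine and fluorine, even though the entering group brings a triple bond and a hydrogen-bond acceptor that the leaving group lacks. No measurement is available that bears on why the two groups read alike.

Still open, as far as these compounds go, is whether a phenyl ring bearing an amine or a carboxylic acid at this place would separate from compound 2 and compound 4 in this assay. Also open, from the compounds shown here alone, is whether the same exchange would read alike with a different group on the other arm of the shared core, as this single step comes from one background only.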